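From bromo to methyl in a weakly active series

A few compounds are considered here, and "the series" means these few. Any claim that something is new, unique, unknown or untested is made for them only; others in the source may bear on it.

Compound 1 `CCOC(=O)c1nn(-c2ccccc2)c(-c2ccc(C)cc2)c1CNC(C)(C)C` gives 86100 nM; > 585000 nM (2 entries) in a functional assay on 786-0 cells (Homo sapiens) for inhibition, read by sulforhodamine B assay, with a stated time of 48 h; on this read-out higher numbers stand for weaker inhibition of growth and lower numbers for stronger inhibition of growth (several entries)
Compound 2 `CC(C)(C)NCc1c(C(=O)O)nn(-c2ccccc2)c1-c1ccc(Cl)cc1` gives > 652000 nM in this assay (a limit)
Compound 3 `CC(C)(C)NCc1c(C(=O)O)nn(-c2ccccc2)c1-c1ccc(Br)cc1` gives > 585000 nM in this assay (a limit)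

Compound 3 stands only at its limit of > 585000 nM and has no number in this assay at all. Compound 4 `Cc1ccc(-c2c(CNC(C)(C)C)c(C(=O)O)nn2-c2ccccc2)cc1` has methyl in place of bromo on an aromatic carbon and is still unmeasured. The nearest measured change is a step that the two limits leave unreadable from compound 2 to compound 3 and it offers no size to carry over. Compound 1 also carries the 4-methylphenyl group, but the several entries of compound 1 in this assay, 86100 nM; > 585000 nM (2 entries) do not agree, and it differs from compound 4 elsewhere. No step beyond the scatter is therefore expected (a step that the limit leaves unreadable from compound 3 to compound 4) in this assay for this change. The estimate for compound 4 is 650000 nM in this assay, with an expected range of 250000 nM to 1000000 nM and a report as a limit the likeliest outcome.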

Compound 4, concentration for 50% growth inhibition: > 688000 nM
Compound 4: no number, only a limit; the forecaster's own chance of this, stated with the estimate: 85%; middle value at least 1.0-fold (0.02 log units) away from the limit.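

In this assay, among the compounds shown here, compound 4 gives > 688000 nM, a limit; compound 2 and compound 3 also stand only at limits, so no step among the three can be read. The compounds shown leave open whether chloro, bromo or methyl at this place makes any difference to growth inhibition.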